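The compounds below may be only part of what the source reports. "The series", "measured", "known", "first", "only" and "open" are said of these compounds alone.

Compound 1 `COc1ccc(-c2c(CNC(C)(C)C)c(C(=O)O)nn2-c2ccccc2)cc1` is tested in a functional assay on NCI-H460 cells (Homo sapiens) for inhibition, read by sulforhodamine B assay, with a stated time of 48 h; a higher number here means a weaker inhibitor of growth, a lower number a stronger inhibitor of growth. In this assay compound 1 gives only a limit, > 659000 nM. Compound 2 `CC(C)(C)NCc1c(C(=O)O)nn(-c2ccccc2)c1-c1ccc([N+](=O)[O-])cc1` carries nitro in place of methoxy on an aromatic carbon. In this assay compound 2 likewise gives only a limit, > 634000 nM. Compound 3 `COc1ccc(-c2c(CNC(C)(C)C)c(C(=O)O)nn2-c2ccc(Cl)cc2)cc1` differs from compound 1 by chloro in place of hydrogen on an aromatic carbon. In this assay compound 3 also gives only a limit, > 605000 nM. The step that the two limits leave unreadable from compound 1 to compound 2 and the step that the two limits leave unreadable from compound 1 to compound 3 therefore cannot be sized; the limits (the limit of > 659000 nM in this assay, at which 1 of the 3 values shown sits), the limit of > 634000 nM in this assay, at which 1 of the 3 values shown sits, and the limit of > 605000 nM in this assay, at which 1 of the 3 values shown sits, are all that the three values show. Compound 4 `CC(C)(C)NCc1c(C(=O)O)nn(-c2ccc(Cl)cc2)c1-c1ccc([N+](=O)[O-])cc1` is not yet measured; it differs from compound 3 by nitro in place of methoxy on an aromatic carbon, the same change as that from compound 1 to compound 2. A step that the limit leaves unreadable from compound 3 to compound 4 is expected, resting on compound 1 and the unreadable step that the two limits leave unreadable from compound 1 to compound 2. Compound 4 is expected to give 700000 nM, between 300000 nM and 2000000 nM, most probably as a limit once more.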

Compound 4, concentration for 50% growth inhibition: 141000 nM
Beside the measured number, compound 4's estimate is 5.0-fold (0.70 log units) above it; the measured number lies below the stated range.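

In this assay, nitro in place of methoxy gives an at least 4.2-fold lower number from compound 3 to compound 4 (0.63 log units; beyond the scatter), and chloro in place of hydrogen gives an at least 4.4-fold lower number from compound 2 to compound 4 (0.65 log units; beyond the scatter). The same nitro change on the core of compound 1 cannot be read, and neither can the other steps among the limits, so this does not show whether the change carries over from one core to the other or keeps its size. Compound 3 gives only a limit: the limit of > 605000 nM in this assay, at which 1 of the 4 values shown sits.

The compounds shown leave open whether a nitrile or a trifluoromethyl group in place of nitro, or bromo in place of chloro, would also give a measurable number in this assay. They also leave open what a methyl ester or an amide in place of the carboxylic acid would do to these numbers.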